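Swapping Chloro for Amino on a Shared Core

A few compounds are considered here, and "the series" means these few. Any claim that something is new, unique, unknown or untested is made for them only; others in the source may bear on it.

Measured compounds:
compound 1 `Nc1nn(C(=O)Nc2ccc(Cc3ccccc3)cc2)c2ccccc12` — 16700 nM
compound 2 `Nc1nn(C(=O)Nc2ccc(Cc3ccccc3)cc2)c2ccc(Cl)cc12` — 16100 nM

Compound 1 and compound 2 share one core and differ at a single aromatic carbon. In a functional assay on A498 cells (Homo sapiens) for antiproliferative activity, read by sulforhodamine B assay, with a stated time of 48 h (on this read-out higher numbers stand for weaker inhibition of growth and lower numbers for stronger inhibition of growth), compound 1 gives 16700 nM and compound 2 gives 16100 nM. For the measured compounds named here, the only measured step, a 1.0-fold lower number from compound 1 to compound 2 (0.02 log units; within the scatter), shows that putting chloro in place of hydrogen at that carbon left the number essentially unchanged. Compound 2 therefore stands as the lowest of the two numbers, but since its gap to compound 1 lies within the scatter, the two cannot be told apart.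

Compound 3 `Nc1ccc2c(c1)c(N)nn2C(=O)Nc1ccc(Cc2ccccc2)cc1` is the next change at the same place: amino in place of chloro on an aromatic carbon. Going by the values given here, the one measured step bears on it only in that it concerns the same carbon; it tells nothing about amino itself, which unlike chloro brings a hydrogen-bond donor and acceptor. Among the compounds with values here, with no step that speaks to such a group, the expectation for this assay rests on the tolerance already seen, so no step beyond the scatter is expected, a 1.0-fold lower number from compound 2 to compound 3 (0.00 log units; within the scatter). For compound 3 the estimated value is 16000 nM, expected to fall between 6000 nM and 45000 nM.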

Compound 3, concentration for 50% growth inhibition: 14400 nM
Estimate against measurement, compound 3: 1.1-fold (0.05 log units) above; the range from low to high includes it.
By their numbers in this assay, from the lowest: compounds 3, 2 and 1 (each within the scatter of the next).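

In this assay the swap at this aromatic carbon gives a 1.1-fold lower number from compound 2 to compound 3 (0.05 log units; within the scatter) and, set against the parent with hydrogen at the same carbon, a 1.2-fold lower number from compound 1 to compound 3 (0.06 log units; within the scatter) as the second reading. Hydrogen, chloro and amino have now all been placed here, and the three numbers cannot be told apart, so the tolerance seen with chloro also holds for a group of a different kind, since amino counts a hydrogen-bond donor and a hydrogen-bond acceptor where chloro counts neither. No measurement shown here accounts for this flat result, so the finding stays a plain observation about these three compounds and carries no explanation.

Going by these compounds, what remains open is whether this carbon tolerates everything or only small groups of a single heavy atom, which a carboxylic acid, a methoxy group or a longer chain such as butoxy in the same place would test. The compounds shown also leave open whether any change to the shared core can move the number beyond the scatter, since every step so far stays within it and all of them fall on this one carbon.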